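The compounds below may be only part of what the source reports. "The series", "measured", "known", "first", "only" and "open" are said of these compounds alone.

Measured so far:
- compound 1 `O=C(CSC(=S)N[C@H]1CCOC1=O)Nc1ccccc1Cl` — in a functional assay on MCF7 cells (Homo sapiens) for cytotoxicity, read by MTT assay, with a stated time of 72 h (a higher number here means a weaker inhibitor, a lower number a stronger inhibitor), compound 1 gives 90800 nM
- compound 2 `Cc1ccc(NC(=O)CSC(=S)N[C@H]2CCOC2=O)cc1` — in this assay compound 2 gives 33500 nM

Among the measured compounds shown here, compound 2 stands at the lowest of the two numbers; its nearest neighbour is compound 1, and the only step available, a 2.7-fold lower number from compound 1 to compound 2 (0.43 log units; beyond the scatter), puts the two apart by more than the usual scatter.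

Compound 3 `O=C(CSC(=S)N[C@H]1CCOC1=O)Nc1ccc(F)cc1` differs from compound 2 by fluoro in place of methyl on an aromatic carbon, on an aromatic carbon of the six-membered ring of carbon only, para to a large group. For the measured compounds named here, no measured step swaps one para substituent for another; the single step in hand changes both the group and its place at once, so it bears only loosely on this change. With so little to go on, the expectation is a step of about a 1.2-fold higher number from compound 2 to compound 3 (0.08 log units; within the scatter) in this assay, close to the scatter and with no firm direction. Compound 3 is therefore estimated at 40000 nM, in the range 15000 nM to 110000 nM.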

Compound 3, half-maximal inhibitory concentration: 5830 nM
The estimate for compound 3 lay 6.9-fold (0.84 log units) above the measured number; the measured number lies below the stated range.
By their numbers in this assay, from the lowest: compound 3; then compound 2; then compound 1.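

In this assay the aromatic carbon para to a large group proves sensitive: fluoro in place of methyl gives a 5.7-fold lower number from compound 2 to compound 3 (0.76 log units; beyond the scatter) for the exchange of one heavy atom for another, with no hydrogen-bond donor or acceptor entering or leaving. The 4-fluorophenyl group also separates clearly from the 2-chlorophenyl group, with a 16-fold lower number from compound 1 to compound 3 (1.19 log units; beyond the scatter) and compound 3 now holding the lowest number, its steps to both others being beyond the scatter. No supporting measurement is available to explain these steps.

As far as these compounds go, whether the lower number is particular to fluoro remains open, and chloro, methoxy, trifluoromethyl or an amine at this place would test that. Also open, from the compounds shown here alone, is whether the 4-fluorophenyl result carries over to changes elsewhere on the shared core, such as a longer chain before the amide.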